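Thiosemicarbazide series: from free hydrazide to arylidene hydrazone

The source may report more compounds than this note shows. Statements on the series, on what has been measured and on what is new or still open speak of the compounds shown alone.

Measured compounds:
compound 1 `CC1=CC[C@H](C(C)(C)NC(=S)NN)CC1` — 900 nM
compound 2 `CC1=CC[C@H](C(C)(C)NC(=S)N/N=C/c2ccccc2Cl)CC1` — 11000 nM

Two compounds have numbers in a functional assay on MCF7 cells (Homo sapiens) for inhibition, read by sulforhodamine B assay, with a stated time of 48 h; on this read-out higher numbers stand for weaker inhibition of growth and lower numbers for stronger inhibition of growth. Compound 1 gives 900 nM, the lowest number of the two. Compound 2 gives 11000 nM, a higher number that lies well beyond the scatter. Within the data shown here, compound 2 differs from compound 1 at the terminal nitrogen, where a chlorinated benzylidene group replaces the free amino group; no step is computed for that pair, so only the two numbers themselves speak.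

Compound 3 `CC1=CC[C@H](C(C)(C)NC(=S)N/N=C/c2ccc[nH]2)CC1` is not yet measured. It differs from compound 1 as follows: a group of 7 heavy atoms (5 carbon, 2 nitrogen; one five-membered aromatic ring with 1 hetero atom) in place of one nitrogen atom, on an amide-type nitrogen. This is the same kind of exchange seen between compound 1 and compound 2, with a five-membered aromatic ring with 1 hetero atom entering instead of the chlorinated six-membered ring.

Among the measured compounds shown here, no computed step exists for this change. A step toward weaker inhibition of growth, beyond the scatter, is expected from compound 1 to compound 3 because compound 2 gives 11000 nM. The size of the expected step in this assay is a 5.6-fold higher number from compound 1 to compound 3 (0.74 log units; beyond the scatter). For compound 3 the estimate is 5000 nM, within a range of 1500 nM to 15000 nM.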

Compound 3, concentration for 50% growth inhibition: 3900 nM
Estimate against measurement, compound 3: 1.3-fold (0.11 log units) above; low and high end bracket the measured number.
By their numbers in this assay, from the lowest: compound 1; then compound 3; then compound 2.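

In this assay, the penalty for replacing the amino group on the amide-type nitrogen is not confined to the 2-chlorophenyl hydrazone, as the 1H-pyrrol-2-yl hydrazone also gives a 4.3-fold higher number from compound 1 to compound 3 (0.64 log units; beyond the scatter). The group on the carbon with a double bond to nitrogen also sets the size of that penalty: 1H-pyrrol-2-yl in place of 2-chlorophenyl gives a 2.8-fold lower number from compound 2 to compound 3 (0.45 log units; beyond the scatter), recovering part of the loss but leaving compound 1 with the lowest number of the three. No available evidence accounts for either step.

The two hydrazones differ in both ring and chlorine, so they cannot show whether the gap follows the chlorine atom or the ring itself, and an unsubstituted phenyl group on that carbon would separate the two. As far as these compounds go, it also remains open whether a small group such as methyl in place of the ring would bring the number closer to that of compound 1, or whether any hydrazone of this kind can match the free amino group.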